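This account rests on a few compounds, and the source may have more. Where it says the series, first, only, none or still open, it means among the compounds named here.

Among the compounds with values here, compound 2 `Cc1ccc(C(=O)NC(=N)NCCCCc2ccccc2)cc1` holds the lower of the two numbers so far obtained in an assay on CHO cells for inhibition of sodium channel protein type 2 subunit alpha (Homo sapiens) (on this read-out higher numbers stand for weaker inhibition and lower numbers for stronger inhibition), where compound 2 gives 1140 nM. Within the data shown here, its only neighbour is compound 1 `Cc1ccc(C(=O)NC(=N)NCCCc2ccccc2)cc1`, which in this assay gives 6030 nM. Among the measured compounds shown here, the step between them, a 5.3-fold lower number from compound 1 to compound 2 (0.72 log units; beyond the scatter), is modest, and it is the only measured step available. Compound 3 `Cc1ccc(C(=O)NC(=N)NCCCCCc2ccccc2)cc1` has not yet been measured. It differs from compound 2 by benzyl in place of phenyl on a saturated chain carbon, four bonds along the chain from an amine nitrogen; the same difference, cut one bond further out, reads benzyl to phenethyl. For the measured compounds named here, the single step that bears on this change, a 5.3-fold lower number from compound 1 to compound 2 (0.72 log units; beyond the scatter), lowered the number when the chain was lengthened in the same way one bond closer to the amine nitrogen. Whether a further lengthening does the same cannot be read from two compounds alone, so in this assay a step smaller than the earlier one, or none beyond the scatter, is expected. Compound 3 is therefore estimated to give 700 nM, with a range from 250 nM to 2500 nM. This amounts to an expected step of a 1.6-fold lower number from compound 2 to compound 3 (0.21 log units; within the scatter).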

Compound 3, half-maximal inhibitory concentration: 2110 nM
Compound 3: the middle estimate sits 3.0-fold (0.48 log units) below what was measured, within the range that was stated.
By their numbers in this assay, from the lowest: compounds 2 and 3 (each within the scatter of the next); then compound 1.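

In this assay, within the data shown here, the change to the chain at this position no longer gives a step that can be told from the scatter: benzyl gives way to phenethyl with a 1.9-fold higher number from compound 2 to compound 3 (0.27 log units; within the scatter), whereas the earlier change from phenyl to benzyl, one bond closer to the amine nitrogen, gave a step beyond it. Compound 3 nevertheless stays clearly apart from compound 1, with a 2.9-fold lower number from compound 1 to compound 3 (0.46 log units; beyond the scatter), so the two longer chains share a similar level in this assay and the shortest chain of the three stands apart from both, which suggests a levelling of the number rather than a continued fall over these three compounds only. What lies behind this levelling cannot be said, as nothing available here bears on the result.

Three compounds cannot show whether a still longer chain would keep the number at this level or carry it back towards that of compound 1. Nor do they show whether the chain length matters in the same way when the end phenyl is replaced by a cyclohexyl ring, or when an ether oxygen is placed within the chain.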